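Alkyl chain lengthening from compound 1 to compound 3

The compounds below may be only part of what the source reports. "The series", "measured", "known", "first", "only" and "open" are said of these compounds alone.

Going by the values given here, in a functional assay on EC9706 cells (Homo sapiens) for antiproliferative activity, read by MTT assay, with a stated time of 48 h (a lower number here means a stronger inhibitor, a higher number a weaker inhibitor), compound 1 `CCCCCCCCn1cc(COC[C@@H]2OC[C@H](N)[C@@H]2O)nn1` gives 44300 nM as the higher of the two numbers measured so far, which makes it the weaker inhibitor of the pair. Compound 2 `CCCCCCCCCCCCn1cc(COC[C@@H]2OC[C@H](N)[C@@H]2O)nn1` gives 16000 nM in the same read-out. Among the compounds with values here, the only measured step bearing on the change is a 2.8-fold lower number from compound 1 to compound 2 (0.44 log units; beyond the scatter) for butyl in place of hydrogen on a saturated chain carbon, a modest step but beyond the scatter. Compound 3 `CCCCCCCCCCCCCCCCn1cc(COC[C@@H]2OC[C@H](N)[C@@H]2O)nn1` carries octyl in place of hydrogen on a saturated chain carbon, eight bonds along the chain from an aromatic nitrogen at that same place, a longer addition than butyl. Within the data shown here, on the single step of a 2.8-fold lower number from compound 1 to compound 2 (0.44 log units; beyond the scatter) a further move to a lower number is expected in this assay, though one step cannot show whether the trend continues. The expected step is a 5.5-fold lower number from compound 1 to compound 3 (0.74 log units; beyond the scatter) in this read-out. Compound 3 is estimated at 8000 nM within a range from 2500 nM to 27000 nM as an expectation only.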

Compound 3, half-maximal inhibitory concentration: 20000 nM
The estimate for compound 3 lay 2.5-fold (0.40 log units) below the measured number; the measured number falls inside the stated range.
By their numbers in this assay, from the lowest: compounds 2 and 3 (each within the scatter of the next); then compound 1.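

In this assay octyl in place of hydrogen on a saturated chain carbon, eight bonds along the chain from an aromatic nitrogen, gives a 2.2-fold lower number from compound 1 to compound 3 (0.35 log units; beyond the scatter) and so keeps a modest gain at this position with the larger addition. Butyl in place of hydrogen on a saturated chain carbon gives a 1.3-fold higher number from compound 2 to compound 3 (0.10 log units; within the scatter) and so adds nothing that can be told from the scatter, which means the drop seen on the first lengthening does not continue through compound 3. No measurement at hand accounts for this levelling.

Open, as far as these compounds go, is whether a chain longer than that of compound 3 holds this level or loses it. Also open, from the compounds shown here alone, is how an amine or a carboxylic acid at the far end of the chain would read in this assay against compound 2.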